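This account rests on a few compounds, and the source may have more. Where it says the series, first, only, none or still open, it means among the compounds named here.

Values in a functional assay on A549 cells (Homo sapiens) for antiproliferative activity, read by MTT assay, with a stated time of 72 h; a lower number here means a stronger inhibitor, a higher number a weaker inhibitor:
- compound 1 `O=C(N/N=C/c1cccc(Br)c1)Nc1ccc(Oc2ccnc3[nH]ccc23)c(F)c1`: 2220 nM
- compound 2 `N#Cc1ccc(/C=N/NC(=O)Nc2ccc(Oc3ccnc4[nH]ccc34)c(F)c2)cc1`: 1360 nM
- compound 3 `O=C(N/N=C/c1ccc([N+](=O)[O-])cc1)Nc1ccc(Oc2ccnc3[nH]ccc23)c(F)c1`: 20 nM

Compound 3 has the lowest number of the three, which makes it the strongest inhibitor of this small set. Both steps that lead to it are large and beyond the scatter: a 110-fold lower number from compound 1 to compound 3 (2.05 log units; beyond the scatter) and a 68-fold lower number from compound 2 to compound 3 (1.83 log units; beyond the scatter). The remaining step, a 1.6-fold lower number from compound 1 to compound 2 (0.21 log units; within the scatter), lies within the scatter.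

The next compound, compound 4 `O=C(N/N=C/c1ccc(F)cc1Cl)Nc1ccc(Oc2ccnc3[nH]ccc23)c(F)c1`, has not been measured yet. It carries 2-chloro-4-fluorophenyl in place of 4-nitrophenyl on a carbon with a double bond to nitrogen. Within the data shown here, the change therefore removes the one group that compound 3 alone holds among the measured compounds. Compound 1 at 2220 nM and compound 2 at 1360 nM both lack that group, and both sit far above compound 3. A large step to a higher number in this assay is therefore expected, somewhat smaller than or similar to those two large steps. Among the measured compounds shown here, no measured compound carries chlorine or fluorine on this ring, so the range stays wide.

The expected change is a 50-fold higher number from compound 3 to compound 4 (1.70 log units; beyond the scatter). For compound 4 the estimate is 1000 nM, with an expected range from 150 nM to 4000 nM.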

Compound 4, half-maximal inhibitory concentration: 10 nM
For compound 4 the middle estimate is 100-fold (2.00 log units) above the measured one; the whole stated range lies above it.
By their numbers in this assay, from the lowest: compounds 4 and 3 (each within the scatter of the next); then compounds 2 and 1 (each within the scatter of the next).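

In this assay, a 2.0-fold lower number from compound 3 to compound 4 (0.30 log units; within the scatter) lies within the scatter, so at this position on the carbon with a double bond to nitrogen, a low number does not depend on the nitro group: 2-chloro-4-fluorophenyl, which carries neither nitrogen nor oxygen, stands level with 4-nitrophenyl. Compound 4 also stands far from the other two compounds, with a 140-fold lower number from compound 2 to compound 4 (2.13 log units; beyond the scatter) and a 220-fold lower number from compound 1 to compound 4 (2.35 log units; beyond the scatter), both large, so two quite different rings now give low numbers here, while 4-cyanophenyl and 3-bromophenyl do not. The choice of ring at this place clearly matters a great deal, but no available evidence says what separates the two low rings from the other two.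

The compounds shown leave open whether the chlorine or the fluorine alone would be enough, since no ring here carries just one of them. From the compounds shown here alone, it also remains open how this ring would behave with an amine, a carboxylic acid or a methoxy group in place of these halogens.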